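A few compounds are considered here, and "the series" means these few. Any claim that something is new, unique, unknown or untested is made for them only; others in the source may bear on it.

Measured so far in a functional assay on HUVEC cells (Homo sapiens); on this read-out lower numbers stand for an effect already at smaller amounts and higher numbers for an effect only at larger amounts of compound:
- Compound 1 `COC1=C(C)C(=O)/C(=C(O)/C=C/c2ccc(O)cc2)C(=O)C1(C)C`: < 4 ug/mL (a limit)
- Compound 2 `CCc1ccc(/C=C/C(O)=C2/C(=O)C(C)=C(OC)C(C)(C)C2=O)cc1`: < 4 ug/mL (a limit)

In this assay, going by these compounds, compound 2 gives < 4 ug/mL, which is a limit and not a number, so its exact place on this read-out is unknown. Compound 1 gives < 4 ug/mL, also a limit. The unmeasured compound 3 `COC1=C(C)C(=O)/C(=C(O)/C=C/c2ccco2)C(=O)C1(C)C` departs from compound 2 in one place, with furan-2-yl in place of 4-ethylphenyl on a double-bonded chain carbon bound to a double-bonded chain carbon.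

Among the compounds with values here, only one measured step bears on this change, and only loosely. It is a step that the two limits leave unreadable from compound 1 to compound 2, with ethyl in place of hydroxy on an aromatic carbon. Its size cannot be read, as the limit of < 4 ug/mL in this assay, at which 2 of the 2 values shown sit, shows. That step also touches only a substituent on the aromatic ring, whereas compound 3 replaces the ring itself. The data therefore give no direction for the change in this assay, and no step beyond the scatter is assumed.

The expected step is a step that the limit leaves unreadable from compound 2 to compound 3. For compound 3 the estimate is 3 ug/mL, with an expected range from 1 ug/mL to 10 ug/mL.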

Compound 3, concentration for half-maximal effect: < 4 ug/mL
Compound 3 was reported as a limit (the forecaster's own chance of this, stated with the estimate: 50%); the middle value does not contradict the limit.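

In this assay compound 3 gives < 4 ug/mL as a limit and not a number. Within the data shown here, no step among compound 1, compound 2 and compound 3 can be read, as all three sit at the same limit: the limit of < 4 ug/mL in this assay, at which 3 of the 3 values shown sit. The compounds shown leave open whether 4-hydroxyphenyl, 4-ethylphenyl and furan-2-yl differ at all on this read-out.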